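The source may hold more compounds than are shown below. What is called first, only, known or untested is meant among the compounds shown, and "the series" means these compounds.

Compound 2, `COc1cc(OC)c(OC)cc1/C=C/COC(=O)/C=C/c1ccc(Br)cc1`, is an analogue of compound 1, `COc1cc(OC)c(OC)cc1/C=C/COC(=O)/C=C/c1ccc(OC)c(OC)c1`, and both have been tested in a functional assay on the whole organism (strain Kunming) with Mus musculus as the target, with a stated time of 0.5 h, at a dose of 100 mg/kg by the intraperitoneal route; a higher number here means a weaker effect of the compound at the dose given, a lower number a stronger effect. In this assay compound 1 gives 100%. In this assay compound 2 gives 100%. The step of no change at the digits printed from compound 1 to compound 2 (within the scatter) shows that putting 4-bromophenyl in place of 3,4-dimethoxyphenyl on the double-bonded chain carbon bound to a double-bonded chain carbon left the read-out where it was, so compound 2 stands level with compound 1 on the numbers at hand.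

Compound 3, `COc1cc(OC)c(OC)cc1/C=C/COC(=O)/C=C/c1cccc(Br)c1`, has not yet been measured in this assay. It differs from compound 2 in a single respect: 3-bromophenyl in place of 4-bromophenyl on a double-bonded chain carbon bound to a double-bonded chain carbon. Among the compounds with values here, the one measured step that touches this part of the molecule is the exchange from compound 1 to compound 2, and no measured pair compares 4-bromophenyl with 3-bromophenyl directly. Within the data shown here, because no change at the digits printed from compound 1 to compound 2 (within the scatter) is the only guide for this region, compound 3 is expected to remain level with compound 2, with an estimated step of no change at the digits printed from compound 2 to compound 3 (within the scatter). Compound 3 is therefore estimated to give 100% in this assay, within a range from 85% to 100%.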

Compound 3, a percentage reported as activity, at one dose (the size of the read-out at that dose, not a potency): 100%
Estimate against measurement, compound 3: no gap at the digits printed; the range from low to high includes it.
By their numbers in this assay, from the lowest: compounds 1, 2 and 3 (each within the scatter of the next).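

In this assay, within the data shown here, 3-bromophenyl in place of 4-bromophenyl on a double-bonded chain carbon bound to a double-bonded chain carbon gave no change at the digits printed from compound 2 to compound 3 (within the scatter) and so provides the first direct comparison of these two groups, which have the same atoms joined differently. Against the 3,4-dimethoxyphenyl group of compound 1, the same group gave no change at the digits printed from compound 1 to compound 3 (within the scatter) and so extends the earlier result to a third group at this place, with none of the three separated from the others by this read-out. No evidence is available to explain why these exchanges leave the read-out unmoved.

The compounds shown leave open whether any group at this place can shift the read-out from this shared level, for instance an amine or a carboxylic acid on the phenyl ring, or a longer chain in place of the ring. They also leave open whether changes elsewhere on the shared core would matter, since all three compounds carry it unchanged and were compared at a single dose.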